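A few compounds are considered here, and "the series" means these few. Any claim that something is new, unique, unknown or untested is made for them only; others in the source may bear on it.

Working notes on the series. The shared core carries a propyl chain and a dicyclopropylmethyl group on the same nitrogen, and a dimethoxyphenyl ring on the core. Compound 1 `CCCN(c1nccc(-c2ccc(OC)cc2OC)n1)C(C1CC1)C1CC1` is the unsubstituted parent; in an assay on CHO cells for displacement of a labelled ligand from corticotropin-releasing factor receptor 1 (Homo sapiens) (on this read-out lower numbers stand for stronger inhibition and higher numbers for weaker inhibition), compound 1 gives 460 nM. Compound 2 `CCCN(c1ncc(C)c(-c2ccc(OC)cc2OC)n1)C(C1CC1)C1CC1` carries a methyl on the core; in this assay compound 2 gives 19 nM. Within the data shown here, the single step measured so far, a 24-fold lower number from compound 1 to compound 2 (1.38 log units; beyond the scatter), is methyl in place of hydrogen on an aromatic carbon, and it is the only change recorded in this set. On the two numbers shown, compound 2 stands at the lower end, with compound 1 as its only neighbour at a higher number, beyond the scatter.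

Compound 3 `CCCN(c1ncc(CC)c(-c2ccc(OC)cc2OC)n1)C(C1CC1)C1CC1` extends the same group: methyl in place of hydrogen on a saturated chain carbon bound to an aromatic carbon. Among the measured compounds shown here, no measured step covers a methyl-to-ethyl change here, so the large gain seen from compound 1 to compound 2 cannot simply be carried forward; the first carbon is already in place in compound 2, and adding a second one is a different, smaller change. The expectation for compound 3 is therefore a step of about a 1.3-fold lower number from compound 2 to compound 3 (0.10 log units; within the scatter) in this assay, not clearly beyond the scatter in either direction. Compound 3 is estimated at 15 nM, with a range from 4 nM to 60 nM.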

Compound 3, inhibition constant: 860 nM
For compound 3 the middle estimate is 57-fold (1.76 log units) below the measured one; the measured number lies above the stated range.
By their numbers in this assay, from the lowest: compound 2; then compounds 1 and 3 (each within the scatter of the next).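

At this position on the core, the methyl-to-ethyl change is not a small extension of the earlier gain: it gives a 45-fold higher number from compound 2 to compound 3 (1.66 log units; beyond the scatter) and so removes the whole advantage seen with methyl. Read against the unsubstituted parent, the ethyl group gives a 1.9-fold higher number from compound 1 to compound 3 (0.27 log units; within the scatter) in this assay and leaves compound 3 indistinguishable from compound 1 on this read-out. Among the three compounds, the low number therefore belongs to the methyl of compound 2 alone, and the response at this position does not follow the carbon count in one direction, since the first added carbon and the second pull opposite ways.

Nothing at hand bears on the reason for this reversal. Open, going by these compounds, is where other groups at this position would fall relative to methyl and ethyl, for example a chlorine atom, a methoxy group, a cyclopropyl ring or a longer chain such as propyl.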